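Cyclopropyl to 2,3-Difluorophenyl in a Nitroimidazooxazine Series

This account rests on a few compounds, and the source may have more. Where it says the series, first, only, none or still open, it means among the compounds named here.

Measured so far in an ADME assay on Vero cells (Chlorocebus sabaeus) for cytotoxicity, read by MTT assay, with a stated time of 72 h; on this read-out lower numbers stand for higher toxicity in this test and higher numbers for lower toxicity in this test:
- compound 1, `C[C@]1(CN2CCc3nc(-c4ccc(F)cc4)nnc3C2)Cn2cc([N+](=O)[O-])nc2O1`, gives "not determined" (no result reported).
- compound 2, `C[C@]1(CN2CCc3oc(-c4ccc(F)cc4)nc3C2)Cn2cc([N+](=O)[O-])nc2O1`, gives > 32 ug/mL.
- compound 3, `C[C@]1(CN2CCc3nc(C4CC4)ccc3C2)Cn2cc([N+](=O)[O-])nc2O1`, gives "not determined" (no result reported).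

Compound 2 carries an entry that is a limit of the assay rather than a number, namely > 32 ug/mL. The other two compounds carry no reported result, so compound 3 stands without a number of its own; of the three entries shown, one is a limit and two are empty, and the only concrete point in the set is the one summarised as the limit of > 32 ug/mL in this assay, at which 1 of the 3 values shown sits.

Compound 4, `C[C@]1(CN2CCc3nc(-c4cccc(F)c4F)ccc3C2)Cn2cc([N+](=O)[O-])nc2O1`, is the untested member. It differs from compound 3 in one place: 2,3-difluorophenyl in place of cyclopropyl on an aromatic carbon. Among the measured compounds shown here, because nothing is measured for compound 3, there is no step to anchor this change on, and no pair among the measured compounds follows a comparable exchange.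

For the measured compounds named here, with only a single limit in the set and no measured step, the expectation for this assay is that compound 4 behaves like the one reported compound and shows no toxicity within the tested window, so its result is expected to be another limit rather than a number, with any scatter unknown. On that basis compound 4 is estimated at 40 ug/mL, with a range from 16 ug/mL to 100 ug/mL.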

Compound 4, half-maximal cytotoxic concentration: > 32 ug/mL
Compound 4 was reported as a limit; the forecaster's own chance of this, stated with the estimate: 70%; the middle value does not contradict the limit.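

No step can be read between compound 3 and compound 4, as compound 3 has no value to compare with the limit reported for compound 4. Two of the compounds now share one limit: the limit of > 32 ug/mL in this assay, at which 2 of the 4 values shown sit. On these data alone, the actual cytotoxic concentrations of compound 2 and compound 4 remain open, as does any effect of exchanging cyclopropyl for 2,3-difluorophenyl.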